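A second chlorine on two related chlorinated purines

A few compounds are considered here, and "the series" means these few. Any claim that something is new, unique, unknown or untested is made for them only; others in the source may bear on it.

The compounds here share a chlorinated purine-like core carrying a benzyl arm that itself bears a chloromethyl group; compound 1 `ClCc1ccc(Cn2cnc3c(Cl)ncnc32)cc1` and compound 2 `ClCc1ccccc1Cn1cnc2ncnc(Cl)c21` have the same atoms joined differently, and the difference between the two cores is not broken down here. In a functional assay on EKVX cells (Homo sapiens) for cytotoxicity, read by sulforhodamine B assay, with a stated time of 48 h (on this read-out lower numbers stand for stronger inhibition of growth and higher numbers for weaker inhibition of growth), compound 1 gives 2450 nM, and compound 2 gives 5370 nM, which places compound 2 second highest of the three measured numbers. Compound 3 `ClCc1ccc(Cn2cnc3c(Cl)nc(Cl)nc32)cc1` is compound 1 with one further change, (chloro in place of hydrogen on an aromatic carbon), and in this assay compound 3 gives 17400 nM; the step is a 7.1-fold higher number from compound 1 to compound 3 (0.85 log units; beyond the scatter), so adding the second chlorine weakened the growth inhibition clearly.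

Compound 4 `ClCc1ccccc1Cn1cnc2nc(Cl)nc(Cl)c21` stands to compound 2 as compound 3 stands to compound 1, the change being (chloro in place of hydrogen on an aromatic carbon); the place of the change is described in the same words for both pairs, so the change is the same. Within the data shown here, only one measured example of this change is available, and compounds 1 and 2 differ in how their atoms are joined, so the carry-over is a guess. Still, the expectation for compound 4 is a step of about a 6.5-fold higher number from compound 2 to compound 4 (0.81 log units; beyond the scatter), resting on the weakening seen in the step of a 7.1-fold higher number from compound 1 to compound 3 (0.85 log units; beyond the scatter). Compound 4 is therefore estimated at 35000 nM in this assay, with a plausible range from 12000 nM to 100000 nM.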

Compound 4, concentration for 50% growth inhibition: 1730 nM
Compound 4: the middle estimate sits 20-fold (1.31 log units) above what was measured; measured number outside the range, below it.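

In this assay, placing a chloro on the aromatic carbon between two ring nitrogen atoms gives a 3.1-fold lower number from compound 2 to compound 4 (0.49 log units; beyond the scatter), so on this core the second chlorine strengthened growth inhibition rather than weakening it. A change that looks identical on paper therefore cannot simply be carried from one core to another in this series, since the two measured pairs move in opposite directions by clearly different amounts: the same change on two cores in this assay, a 7.1-fold higher number (0.85 log units; beyond the scatter) from compound 1 to compound 3 and a 3.1-fold lower number (0.49 log units; beyond the scatter) from compound 2 to compound 4, 22-fold (1.34 log units) apart, beyond the scatter of two such steps. Among these compounds, what this does not show is why the two cores respond differently, since there are only two pairs, and the cores of compound 1 and compound 2 differ in how their atoms are joined, so no single structural feature can be held responsible.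

The compounds shown leave open whether this reversal belongs to chloro alone or would also appear with another group on the same carbon, such as an amine or a methoxy group. They also leave open how much the chloromethyl group on the benzyl arm contributes on either core, a question that a comparison with a plain methyl group in its place could address.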